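A few compounds are considered here, and "the series" means these few. Any claim that something is new, unique, unknown or untested is made for them only; others in the source may bear on it.

Measured so far:
Compound 1: `CCCN(CC[C@H]1CC[C@H](NC(=O)/C=C/c2ccc(F)cc2)CC1)[C@H]1CCc2nc(N)sc2C1` — 1 nM
Compound 2: `CCCN(CC[C@H]1CC[C@H](NC(=O)/C=C/c2ccccc2Cl)CC1)[C@H]1CCc2nc(N)sc2C1` — 1.2 nM

Both compounds were tested in an assay on brain for displacement of a labelled ligand from D(3) dopamine receptor (Rattus norvegicus); a lower number here means a stronger inhibitor, a higher number a weaker inhibitor. Within the data shown here, compound 1 gives 1 nM and compound 2 gives 1.2 nM, the only change between them being a 1.2-fold higher number from compound 1 to compound 2 (0.08 log units; within the scatter). Compound 2 thus carries the higher of the two numbers, but the gap to compound 1 lies within the scatter, so the two cannot be told apart.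

Compound 3, `CCCN(CC[C@H]1CC[C@H](NS(=O)(=O)c2cccc(Cl)c2)CC1)[C@H]1CCc2nc(N)sc2C1`, has not yet been measured. It differs from compound 2 in (3-chlorophenyl)sulfonyl in place of (2-(2-chlorophenyl)ethenyl)carbonyl on an amine nitrogen. Among the measured compounds shown here, the one measured step concerns only the aromatic ring attached to the chain, while here the whole group on the amine nitrogen is exchanged, so that step offers no direct guidance; it shows only that the shared core tolerates a change at the far end of this group without loss.

For the measured compounds named here, with no precedent for exchanging the carbonyl-bearing group for a sulfonyl, some weakening is estimated for compound 3, a step of a 5.0-fold higher number from compound 2 to compound 3 (0.70 log units; beyond the scatter) in this assay. Compound 3 is expected to give 6 nM, in the range 1.5 nM to 30 nM.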

Compound 3, inhibition constant: 1.1 nM
Beside the measured number, compound 3's estimate is 5.5-fold (0.74 log units) above it; the measured number lies below the stated range.
By their numbers in this assay, from the lowest: compounds 1, 3 and 2 (each within the scatter of the next).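

In this assay, the earlier pair varied only the aromatic ring at the far end of the group on the amine nitrogen, and the carbonyl and ethenyl link stayed in place. Here that link goes as well: (3-chlorophenyl)sulfonyl in place of (2-(2-chlorophenyl)ethenyl)carbonyl is a 1.1-fold lower number from compound 2 to compound 3 (0.04 log units; within the scatter) and, in place of (2-(4-fluorophenyl)ethenyl)carbonyl, a 1.1-fold higher number from compound 1 to compound 3 (0.04 log units; within the scatter), so this position accepts a sulfonyl as readily as the carbonyl group with its ethenyl link, at least when an aromatic ring is attached. No measurement is available that would explain why these different groups give matching results.

Because the enter group changes its link and its ring pattern in one step, the compounds shown cannot separate the contribution of the sulfonyl from that of the chlorine on the ring. They also leave open whether this tolerance extends to a group without an aromatic ring, such as a small methylsulfonyl, to a longer chain between the sulfonyl and the ring, or to a ring carrying a carboxylic acid or an amine.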